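This account rests on a few compounds, and the source may have more. Where it says the series, first, only, none or still open, it means among the compounds named here.

Among the measured compounds shown here, in an ADME assay on microsomes from liver (Homo sapiens) for metabolic stability (on this read-out lower numbers stand for slow clearance and higher numbers for fast clearance), compound 3 (`C[C@H](NC(=O)Cn1nnc2ccccc2c1=O)c1ccc(F)cc1`) gives 31 mL/min/kg as a measured number, the only one among the three compounds tested so far. Compound 1 (`C[C@H](NC(=O)Cn1nnc2ccccc2c1=O)c1ccc(Cl)cc1`) gives < 9.9 mL/min/kg as a limit of the assay and not a number. Compound 2 (`Cc1ccc([C@H](C)NC(=O)Cn2nnc3ccccc3c2=O)cc1`) gives < 9.9 mL/min/kg as a limit too. Compound 3 therefore stands highest of the three, with the other two sitting at the limit.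

Compound 4 (`C[C@H](NC(=O)Cn1nnc2ccccc2c1=O)c1ccc(OC(F)F)cc1`) has difluoromethoxy in place of fluoro on an aromatic carbon, para to a large group (difluoromethoxy in place of fluoro on an aromatic carbon). For the measured compounds named here, two measured steps bear on this change. Fluoro in place of chloro meant an at least 3.1-fold higher number from compound 1 to compound 3 (0.49 log units; beyond the scatter) and fluoro in place of methyl meant an at least 3.1-fold higher number from compound 2 to compound 3 (0.49 log units; beyond the scatter) as well, so read in reverse, both point to a lower number for compound 4 once fluoro leaves. Neither step involves difluoromethoxy, however, and both sizes rest on limits, so the expectation is loose. The expected move is a 2.2-fold lower number from compound 3 to compound 4 (0.35 log units; beyond the scatter) in this estimate, a modest fall. Compound 4 is expected at 14 mL/min/kg as a middle estimate, with an estimated range from 6 mL/min/kg to 32 mL/min/kg in this assay for the measurement to come.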

Compound 4, clearance: < 9.9 mL/min/kg
Compound 4 gave a limit, no number; the forecaster's own chance of this, stated with the estimate: 30%; middle value at least 1.4-fold (0.15 log units) from the limit.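

In this assay, difluoromethoxy in place of fluoro on an aromatic carbon, para to a large group, gives an at least 3.1-fold lower number from compound 3 to compound 4 (0.49 log units; beyond the scatter). Difluoromethoxy is the first group at this position to bring an oxygen, and it ends like chloro and methyl, in a limit and not a number, so among these four compounds only compound 3, with fluoro, gives a measured number. The size of the new step stays open-ended, and the steps from compound 1 and from compound 2 to compound 4 cannot be read, because both ends of each are limits: the limit of < 9.9 mL/min/kg in this assay, at which 3 of the 4 values shown sit.

On these data alone, whether chloro, methyl and difluoromethoxy differ from one another in this read-out therefore stays open, as the three compounds cannot be ranked. As far as these compounds go, it also stays open whether the fluoro result is particular to that one group, since a nitrile, a methoxy or a trifluoromethyl at this position could give a number like compound 3 or a limit like compound 4.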